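The source may hold more compounds than are shown below. What is called first, only, known or untested is meant among the compounds shown, and "the series" means these compounds.

Of the compounds shown here, two of a shared core have been measured. Compound 1 `O=C(Nc1cccc(-n2cc(-c3ccncc3)c(-c3ccc(Cl)c(O)c3)n2)c1)Nc1ccc(Cl)c(Cl)c1` gives 2400 nM in a functional assay on OVCAR-5 cells (Homo sapiens) for inhibition, read by sulforhodamine B assay, with a stated time of 48 h (on this read-out higher numbers stand for weaker inhibition of growth and lower numbers for stronger inhibition of growth), and compound 2 `O=C(Nc1cccc(-n2cc(-c3ccncc3)c(-c3ccc(Cl)c(O)c3)n2)c1)Nc1cc(C(F)(F)F)cc(C(F)(F)F)c1` gives 875 nM in this assay. On these two numbers compound 1 stands highest, with compound 2 the nearer and only neighbour, whose number is lower by a margin beyond the usual scatter of this kind of measurement.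

Compound 3 `O=C(Nc1cccc(-n2cc(-c3ccncc3)c(-c3ccc(Cl)c(O)c3)n2)c1)Nc1ccc(Cl)c(C(F)(F)F)c1` has not yet been measured in this assay. It differs from compound 1 in one place: trifluoromethyl in place of chloro on an aromatic carbon, the new group sitting on an aromatic carbon of a six-membered aromatic ring of carbon only, ortho to a chloro group and meta to a large group. Among the compounds with values here, whether this change moves the number cannot be read from a measured pair, since no such pair exists here; what the data do show is that compound 2, carrying two trifluoromethyl groups on that ring, gives 875 nM against 2400 nM for compound 1.

Compound 3 is therefore expected to give 1500 nM in this assay, within a range from 600 nM to 4000 nM. The step from compound 1 to compound 3 is expected to be a 1.6-fold lower number from compound 1 to compound 3 (0.20 log units; within the scatter), a modest move toward stronger inhibition that may not exceed the scatter.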

Compound 3, concentration for 50% growth inhibition: 1570 nM
The estimate for compound 3 lay 1.0-fold (0.02 log units) below the measured number, within the range that was stated.
By their numbers in this assay, from the lowest: compounds 2, 3 and 1 (each within the scatter of the next, the first and the last beyond it).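

Within the data shown here, the replacement of chloro by trifluoromethyl on this aromatic carbon, ortho to a chloro group and meta to a large group, gives the first pair that differs in one place, and in this assay it amounts to a 1.5-fold lower number from compound 1 to compound 3 (0.18 log units; within the scatter). This position therefore takes a group of four heavy atoms in place of a single chlorine atom without a difference that can be told apart from the usual scatter of repeated measurements. Nothing shown here speaks to why the two groups read alike in this growth assay.

The compounds shown leave open whether a methoxy group, an amine or a carboxylic acid on this same aromatic carbon would give a number beyond the scatter from that of compound 1. Among these compounds, they also leave open whether the trifluoromethyl-for-chloro change would read the same way with hydrogen in place of the chloro group that stays on this ring, so the single step describes only this one setting.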